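Swapping the aryl group on the ring nitrogen of compound 2

A few compounds are considered here, and "the series" means these few. Any claim that something is new, unique, unknown or untested is made for them only; others in the source may bear on it.

Measured compounds:
- compound 1, `Cc1nc(-c2ccc(Cl)cc2)sc1C1SCC(=O)N1c1ccc(F)c(Cl)c1`: 45.2%
- compound 2, `Cc1nc(Cc2ccc(Cl)cc2)sc1C1SCC(=O)N1c1ccc(F)c(Cl)c1`: 45.1%

Both compounds were tested in a functional assay on the whole organism (strain Wistar albino) for inhibition, with Rattus norvegicus as the target, read by paw edema, with stated times of 1 h and 2 h, at a dose of 40 mg/kg by the oral route; a higher number here means more inhibition at the dose given (going by the name of the read-out), a lower number less inhibition. Going by the values given here, compound 1 gives 45.2% and compound 2 gives 45.1%, so compound 2 holds the lowest of the two numbers, but the single step between them, a number 0.1 percentage points lower from compound 1 to compound 2 (within the scatter), lies within the scatter, and the two values cannot be told apart.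

Compound 3, `Cc1ccc(N2C(=O)CSC2c2sc(Cc3ccc(Cl)cc3)nc2C)cc1`, has not yet been measured. Among the compounds with values here, it differs from compound 2 at a different place than the one step already seen: 4-methylphenyl in place of 3-chloro-4-fluorophenyl on an amide-type nitrogen in a ring. Within the data shown here, no measured step touches this part of the shared core, so the only guide is that the one change made so far, a number 0.1 percentage points lower from compound 1 to compound 2 (within the scatter), left the read-out unchanged.

With nothing pointing either way, compound 3 is expected to sit close to compound 2, with the step of a number 4.1 percentage points lower from compound 2 to compound 3 (within the scatter) as the estimated shift, allowing for a wide band. The estimate for compound 3 is 41%, between 26% and 56%.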

Compound 3, a percentage reported as inhibition, in the whole organism at one dose (the size of the read-out at that dose, not a potency): 61.4%
Compound 3: the middle estimate sits 20.4 percentage points below what was measured, outside the stated range (above it).
By their numbers in this assay, from the lowest: compounds 2 and 1 (each within the scatter of the next); then compound 3.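

In this assay, the group on the amide-type nitrogen is a place where the read-out can move: 4-methylphenyl in place of 3-chloro-4-fluorophenyl gives a number 16.3 percentage points higher from compound 2 to compound 3 (beyond the scatter), whereas the earlier change from 4-chlorophenyl to 4-chlorobenzyl on an aromatic carbon gave a number 0.1 percentage points lower from compound 1 to compound 2 (within the scatter). The swap keeps the six-membered aromatic carbon ring and the zero counts of hydrogen-bond donors and acceptors, but it removes both the chlorine and the fluorine and brings in a methyl group, so several things change in this one step. No measurement shown here explains the rise.

On these data alone, it remains open whether the step follows the loss of the halogens or the gain of the methyl group, and an unsubstituted phenyl or a 4-chlorophenyl on the same nitrogen would help to separate the two. As far as these compounds go, it also remains open whether a larger group at that place, such as 4-methoxyphenyl, would carry the read-out further, and whether the gain would hold at other doses, since each number describes a single dose and is not a potency.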